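The source may report more compounds than this note shows. Statements on the series, on what has been measured and on what is new or still open speak of the compounds shown alone.

Compound 3 `NS(=O)(=O)c1cc(-c2nnc(Cn3cc(-c4ccccc4)nn3)o2)c(Cl)cc1SCc1ccccc1` gives 0.21 h in an ADME assay on microsomes from liver (Homo sapiens) for metabolic stability, read by LC-MS, using NADPH, tested at 5 uM; a lower number here means that the compound disappears faster, a higher number that the compound lasts longer. Compound 2 `CCOC(=O)c1cn(Cc2nnc(-c3cc(S(N)(=O)=O)c(SCc4ccccc4)cc3Cl)o2)nn1` gives 0.085 h in this assay. Of the two numbers on hand, compound 3 holds the higher, and the step between them is a 2.5-fold higher number from compound 2 to compound 3 (0.39 log units; beyond the scatter), with a phenyl group taking the spot that the ethoxycarbonyl group holds in compound 2. Compound 1 `[N-]=[N+]=NCc1nnc(-c2cc(S(N)(=O)=O)c(SCc3ccccc3)cc2Cl)o1` is a separate case: in this assay compound 1 gives > 1 h, and this is a limit of the measurement rather than a number (the limit of > 1 h in this assay, at which 1 of the 3 values shown sits). Starting from that limit, the steps were an at least 11-fold lower number from compound 1 to compound 2 (1.07 log units; beyond the scatter) and an at least 4.7-fold lower number from compound 1 to compound 3 (0.67 log units; beyond the scatter), each time a triazolyl group replacing azido on a saturated chain carbon bound to an aromatic carbon.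

Compound 4 `NS(=O)(=O)c1cc(-c2nnc(/C=C/c3ccccc3)o2)c(Cl)cc1SCc1ccccc1` has not yet been measured. The change from compound 3 to compound 4 is 2-phenylethenyl in place of (4-phenyl-1H-1,2,3-triazol-1-yl)methyl on an aromatic carbon. Within the data shown here, no measured step exchanges a triazole for an alkene directly, so the expectation rests on what the three measured values show: both triazole-bearing compounds, compound 2 and compound 3, sit far below the limit reached by compound 1, and among them the one carrying phenyl lasted longer. Removing the triazole while keeping a phenyl is therefore expected to bring a step of a 2.4-fold higher number from compound 3 to compound 4 (0.38 log units; beyond the scatter), upward. Compound 4 is expected to give about 0.5 h, most likely between 0.15 h and 1.5 h.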

Compound 4, half-life: 0.228 h
Beside the measured number, compound 4's estimate is 2.2-fold (0.34 log units) above it; the range from low to high includes it.
By their numbers in this assay, from the lowest: compound 2; then compounds 3 and 4 (each within the scatter of the next). At a limit, above all of these: compound 1.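

In this assay, replacing (4-phenyl-1H-1,2,3-triazol-1-yl)methyl with 2-phenylethenyl removes the triazole ring and keeps a phenyl ring, and the result is a 1.1-fold higher number from compound 3 to compound 4 (0.04 log units; within the scatter), so at this position a short half-life is seen both with and without the triazole ring. Compound 4 also keeps the gap to the ester-bearing compound, with a 2.7-fold higher number from compound 2 to compound 4 (0.43 log units; beyond the scatter), which leaves the two compounds ending in phenyl together, apart from compound 2. The azidomethyl group stays the exception among the four, as the step reads an at least 4.3-fold lower number from compound 1 to compound 4 (0.64 log units; beyond the scatter), and its starting point is a limit rather than a number: the limit of > 1 h in this assay, at which 1 of the 4 values shown sits.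

The compounds shown do not tell whether the double bond matters, and a saturated chain in that place, or an amine or a carboxylic acid on the phenyl ring, would test how far the half-life can move from this end of the molecule. They also leave open which part of these molecules is lost in the microsomes, as all four share the same core.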